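Chain acid swap from compound 3 to compound 4

This account rests on a few compounds, and the source may have more. Where it says the series, first, only, none or still open, it means among the compounds named here.

In an ADME assay on the whole organism (strain CD-1) for metabolic stability, with Mus musculus as the target, at a dose of 3 mg/kg by the intravenous route (a lower number here means that the compound disappears faster, a higher number that the compound lasts longer), compound 1 `CN(Cc1ccccc1OCCCCCC(=O)O)C(=O)c1ccc(-c2ccco2)cc1` gives 1.7 h and compound 2 `C[C@@H](CCCOc1ccccc1CN(C)C(=O)c1ccc(-c2ccco2)cc1)CC(=O)O` gives 2 h while compound 3 `CN(Cc1ccccc1OCCC[C@@H]1C[C@@H]1C(=O)O)C(=O)c1ccc(-c2ccco2)cc1` gives 2.7 h and so stands within the scatter of both. Compound 4 `C/C(=C\CCCOc1ccccc1CN(C)C(=O)c1ccc(-c2ccco2)cc1)C(=O)O` carries 2-carboxyprop-1-en-1-yl in place of 2-carboxycyclopropyl on a saturated chain carbon, three bonds along the chain from an oxygen on an aromatic ring with 2-carboxyprop-1-en-1-yl in place of 2-carboxycyclopropyl on a saturated chain carbon. Within the data shown here, two measured steps touch this place, namely a 1.6-fold higher number from compound 1 to compound 3 (0.20 log units; within the scatter) and a 1.4-fold higher number from compound 2 to compound 3 (0.13 log units; within the scatter) and neither leaves the scatter. The methyl step a 1.2-fold higher number from compound 1 to compound 2 (0.07 log units; within the scatter) also stays inside it. Among the measured compounds shown here, no measured compound has a chain double bond, so the precedent is indirect. No step beyond the scatter is expected in this assay and the estimated step reads a 1.2-fold lower number from compound 3 to compound 4 (0.09 log units; within the scatter) with no firm direction. The estimate for compound 4 is 2.2 h with 1.1 h to 4.2 h as the expected range.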

Compound 4, half-life: 1.2 h
The estimate for compound 4 lay 1.8-fold (0.26 log units) above the measured number, within the range that was stated.
By their numbers in this assay, from the lowest: compounds 4, 1, 2 and 3 (each within the scatter of the next, the first and the last beyond it).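

In this assay, 2-carboxyprop-1-en-1-yl gives the only step beyond the scatter among those shown at this place, on a saturated chain carbon, three bonds along the chain from an oxygen on an aromatic ring (a 2.3-fold lower number from compound 3 to compound 4 (0.35 log units; beyond the scatter)). Against the open saturated chains, the same group stays within the scatter (a 1.7-fold lower number from compound 2 to compound 4 (0.22 log units; within the scatter); a 1.4-fold lower number from compound 1 to compound 4 (0.15 log units; within the scatter)). The change therefore separates only from the 2-carboxycyclopropyl group, and modestly.

Open, on these data alone, is whether the lower half-life goes with the double bond or with its methyl, and how a tetrazole in place of the carboxylic acid, or a longer chain, would read. No evidence on the cause of this step is available.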